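Capping the phenolic hydroxyl of the pyrrolidinyl-octyloxy flavone series

A few compounds are considered here, and "the series" means these few. Any claim that something is new, unique, unknown or untested is made for them only; others in the source may bear on it.

Compound 3 `O=c1cc(-c2ccccc2O)oc2cc(OCCCCCCCCN3CCCC3)ccc12` carries the highest number of the three measured: in an ADME assay on HepG2 cells (Homo sapiens) for cytotoxicity, read by MTT assay, with a stated time of 48 h, tested at 10 uM (on this read-out lower numbers stand for a weaker effect and higher numbers for a stronger effect at the one concentration tested), compound 3 gives 60.6%. Compound 1 `O=c1cc(-c2ccc(Cl)cc2)oc2cc(OCCCCCCCCN3CCCC3)ccc12` gives 25.7% and compound 2 `O=c1cc(-c2ccccc2)oc2cc(OCCCCCCCCN3CCCC3)ccc12` gives 8.97% in this assay, so the steps of a number 34.9 percentage points higher from compound 1 to compound 3 (beyond the scatter) and a number 51.6 percentage points higher from compound 2 to compound 3 (beyond the scatter) both lead up to compound 3, while the step of a number 16.7 percentage points lower from compound 1 to compound 2 (beyond the scatter) goes down.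

Compound 4 `O=c1cc(-c2ccccc2OCc2ccccc2)oc2cc(OCCCCCCCCN3CCCC3)ccc12` differs from compound 3 by benzyl in place of hydrogen on an oxygen on an aromatic ring. None of the three measured steps changes this oxygen; the closest comparison is the step from compound 2 to compound 3, where hydroxy in place of hydrogen raised the number by a large amount, and compound 4 now has neither hydrogen nor hydroxy at that position but benzyloxy. The data give no footing for the direction, so a step of a number 18.6 percentage points lower from compound 3 to compound 4 (beyond the scatter) is expected only as a modest fall with a wide band around it. Compound 4 is thus estimated at 42% in this assay, within 15% to 68%.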

Compound 4, a percentage reported as inhibition, at one concentration (the size of the read-out at that concentration, not a potency): 34.1%
The estimate for compound 4 lay 7.9 percentage points above the measured number; low and high end bracket the measured number.
By their numbers in this assay, from the lowest: compound 2; then compounds 1 and 4 (each within the scatter of the next); then compound 3.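

Placing benzyl on the oxygen of compound 3 gives a number 26.5 percentage points lower from compound 3 to compound 4 (beyond the scatter) in this assay, so the number depends on what sits on this oxygen and not only on the oxygen being present. Even so, the benzyloxy group keeps part of the gain over the unsubstituted ring, with a number 25.1 percentage points higher from compound 2 to compound 4 (beyond the scatter) in the same read-out, so a free hydroxy hydrogen is not needed for a number beyond that of compound 2. Nothing measured here explains either step.

Going by these compounds, it remains open whether this fall is particular to benzyl or would also follow from a methyl or a carboxymethyl group on the same oxygen. On these data alone, it also remains open whether a benzyloxy group would raise the number to the same extent on a ring that also carries the chloro of compound 1.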